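Carbamoyl for hydroxy on the cyclohexyl ring of compound 1

The source may report more compounds than this note shows. Statements on the series, on what has been measured and on what is new or still open speak of the compounds shown alone.

Compound 1: `N#Cc1cnc(NCc2cnccc2C(F)(F)F)cc1N[C@H]1CC[C@@H](O)CC1`, 100 nM
Compound 2: `N#Cc1cnc(NCc2ccccc2C(F)(F)F)cc1N[C@H]1CC[C@H](O)CC1`, 4000 nM

In an assay on isolated protein for inhibition of protein kinase C theta type (Homo sapiens), read by TR-FRET, with a stated time of 2 h (a lower number here means a stronger inhibitor, a higher number a weaker inhibitor), compound 1 gives 100 nM, the lower of the two values measured. Compound 2 gives 4000 nM in this assay, a gap beyond the usual scatter. Compound 3, `N#Cc1cnc(NCc2cnccc2C(F)(F)F)cc1N[C@H]1CC[C@@H](C(N)=O)CC1`, is not yet measured. It differs from compound 1 in one place: carbamoyl in place of hydroxy on a saturated ring carbon. For the measured compounds named here, no measured pair shows this change, so the step of a 1.5-fold higher number from compound 1 to compound 3 (0.18 log units; within the scatter) is expected to be small, perhaps none beyond the scatter, in either direction. Compound 3 is therefore estimated at 150 nM in this assay, within 50 nM to 500 nM.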

Compound 3, half-maximal inhibitory concentration: 7 nM
For compound 3 the middle estimate is 21-fold (1.33 log units) above the measured one; measured number below the stated range.
By their numbers in this assay, from the lowest: compound 3; then compound 1; then compound 2.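

In this assay, carbamoyl in place of hydroxy gives a 14-fold lower number from compound 1 to compound 3 (1.15 log units; beyond the scatter), so the number is sensitive to the group on this saturated ring carbon, and the larger group is accepted there. Hydroxy and carbamoyl have the same counts of hydrogen-bond donors and acceptors, so those counts alone do not separate the two compounds. Nothing shown here accounts for the step. The compounds shown leave open whether a carboxylic acid, an amine or a longer chain ending in carbamoyl would give a similar number at this position.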